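The compounds below may be only part of what the source reports. "The series", "measured", "known", "first", "only" and "open" are said of these compounds alone.

Three compounds have been measured in a functional assay on MDA-MB-231 cells (Homo sapiens) for cytotoxicity, read by sulforhodamine B assay, with a stated time of 48 h, tested at 0.01 uM; a higher number here means a weaker effect of the compound at the concentration tested, a lower number a stronger effect:

Compound 1, `COc1cc(C)cc(-c2nn(CC#N)cc2-c2ccc(-c3cccc(C(C)=O)c3)nc2)c1`, gives 96%.
Compound 2, `Cc1cc(O)cc(-c2nn(CC#N)cc2-c2ccnc(-c3ccc(Oc4ccccc4)cc3)c2)c1`, gives 84%.
Compound 3, `COc1cc(C)cc(-c2nn(CC#N)cc2-c2ccnc(-c3ccc(N(C)C)cc3)c2)c1`, gives 94%.

All three numbers are high, meaning that at the single concentration tested none of the compounds cuts cell growth by much. Compound 3 sits in the middle of the three numbers. Its nearest neighbour is compound 1, whose number is slightly higher, and its furthest is compound 2, whose number is somewhat lower; both gaps lie within the usual scatter of this kind of measurement, so no real difference between the three can be claimed.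

Compound 4, `Cc1cc(O)cc(-c2nn(CC#N)cc2-c2ccnc(-c3ccc(N(C)C)cc3)c2)c1`, has not yet been measured. It differs from compound 3 in one place: hydrogen in place of methyl on an oxygen on an aromatic ring. For the measured compounds named here, no pair of measured compounds shows this change on its own, so its size cannot be read from the data. Because compound 3 gives 94% and the other two numbers lie close to the top of the scale and within scatter of it, the step from compound 3 to compound 4 is expected to be small, with no direction beyond the scatter: a number 4 percentage points lower from compound 3 to compound 4 (within the scatter).

In this assay compound 4 is therefore expected to give about 90%, most likely between 78% and 100%.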

Compound 4, a percentage reported as activity, at one concentration (the size of the read-out at that concentration, not a potency): 98%
Compound 4: middle estimate off by 8 percentage points, on the low side, within the range that was stated.
By their numbers in this assay, from the lowest: compounds 2, 3, 1 and 4 (each within the scatter of the next, the first and the last beyond it).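

Replacing methoxy with hydroxy on the aromatic ring, with the rest of the molecule unchanged, gives in this assay a number 4 percentage points higher from compound 3 to compound 4 (within the scatter), so at this position the methyl on the oxygen makes no difference that can be told from the scatter at this one concentration. For the compounds shown here, the new compound also supplies the first step that clears the scatter, though only modestly: with the 3-hydroxy-5-methylphenyl group held constant, dimethylamino in place of phenoxy on an aromatic carbon gives a number 14 percentage points higher from compound 2 to compound 4 (beyond the scatter), which ties the clearest difference so far to that group and not to the oxygen substituent. Nothing available explains either step, so the data record these differences without accounting for them.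

As far as these compounds go, whether a longer chain on that oxygen, as in ethoxy, or a carboxylic acid in place of dimethylamino would shift the number remains open. All of these readings come from a single concentration, so they say nothing about how the compounds would compare at other concentrations or about their potency.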